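This account rests on a few compounds, and the source may have more. Where it says the series, first, only, none or still open, it means among the compounds named here.

Within the three measured members of the series, compound 3 `Cc1ncccc1-c1cc(F)cc(-n2nnc(-c3ccccn3)n2)c1` stands at the high end in a functional assay for antagonist activity at metabotropic glutamate receptor 5 (Rattus norvegicus) (on this read-out higher numbers stand for weaker inhibition and lower numbers for stronger inhibition), giving 41 nM. Compound 2 `Fc1cc(-c2ccccn2)cc(-n2nnc(-c3ccccn3)n2)c1` in this assay gives 39 nM, and the two sit within the scatter of each other: a 1.1-fold higher number from compound 2 to compound 3 (0.02 log units; within the scatter). Among the measured compounds shown here, compound 1 `N#Cc1ccccc1-c1cc(F)cc(-n2nnc(-c3ccccn3)n2)c1` in this assay gives 6 nM; the steps of a 6.5-fold higher number from compound 1 to compound 2 (0.81 log units; beyond the scatter) and a 6.8-fold higher number from compound 1 to compound 3 (0.83 log units; beyond the scatter) both lie beyond the scatter, so 2-cyanophenyl on that aromatic carbon is the only group of the three tied to a clearly lower number.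

The next compound, compound 4 `Nc1cccnc1-c1cc(F)cc(-n2nnc(-c3ccccn3)n2)c1`, differs from compound 3 in one place: 3-aminopyridin-2-yl in place of 2-methylpyridin-3-yl on an aromatic carbon. For the measured compounds named here, no measured step exchanges this group, so the expectation rests on neighbouring steps. The step of a 1.1-fold higher number from compound 2 to compound 3 (0.02 log units; within the scatter) shows that swapping pyridin-2-yl for 2-methylpyridin-3-yl at this carbon left the number within the scatter; the step of a 6.8-fold higher number from compound 1 to compound 3 (0.83 log units; beyond the scatter) shows that 2-cyanophenyl there gave a modestly lower number. Going by the values given here, the entering 3-aminopyridin-2-yl matches none of the measured groups in kind, so the outcome is open. Compound 4 is therefore expected in this assay at about 30 nM, between 10 nM and 100 nM. The expected step of a 1.4-fold lower number from compound 3 to compound 4 (0.14 log units; within the scatter) is small and likely stays near the scatter.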

Compound 4, half-maximal inhibitory concentration: 19 nM
Compound 4: the middle estimate sits 1.6-fold (0.20 log units) above what was measured; measured number inside the range.
By their numbers in this assay, from the lowest: compound 1; then compound 4; then compounds 2 and 3 (each within the scatter of the next).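

In this assay, adding one group to the pyridin-2-yl at this carbon shifts the number beyond the scatter: amino in place of hydrogen gives a 2.1-fold lower number from compound 2 to compound 4 (0.31 log units; beyond the scatter). Compounds 2 and 3 had stayed within the scatter of each other, but 3-aminopyridin-2-yl also separates from 2-methylpyridin-3-yl, with a 2.2-fold lower number from compound 3 to compound 4 (0.33 log units; beyond the scatter), so groups with one ring nitrogen at this carbon do not all sit at one level. The gain does not close the gap to the 2-cyanophenyl group, as a 3.2-fold higher number from compound 1 to compound 4 (0.50 log units; beyond the scatter) shows, and compound 1 keeps the lowest number of the four. No measurement at hand accounts for the lower number that comes with the amino group.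

The compounds shown leave open whether the shift is specific to amino, since a hydroxyl, methoxy or dimethylamino group on the same pyridin-2-yl would test how far the result depends on that group's identity. They also leave open whether a nitrile on the pyridin-2-yl would bring the number closer to that of compound 1 than amino does.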